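A few compounds are considered here, and "the series" means these few. Any claim that something is new, unique, unknown or untested is made for them only; others in the source may bear on it.

Three compounds share a core carrying a 4-fluorophenyl group and were run in an ADME assay on microsomes from liver (Macaca mulatta) for metabolic stability, with a stated time of 0.5 h, tested at 0.5 mg/mL; on this read-out lower numbers stand for a less stable compound and higher numbers for a more stable compound. Compound 1, with the structure `CN(C)C(=O)CCN1CCc2c(cc(-c3ccc(F)cc3)n2C)C1=O`, gives 42%. Compound 2, with the structure `CC(=O)N1CC2(CC(NC(=O)c3cc(-c4ccc(F)cc4)no3)C2)C1`, gives 79%. Compound 3, with the structure `CC(CNC(=O)c1cc(-c2ccc(F)cc2)no1)C(=O)N(C)C`, gives 52% in this assay.

On these numbers compound 3 holds the second highest of the three. Its nearest neighbour is compound 1, whose number lies lower but within the scatter, so the two cannot be told apart. Its furthest neighbour is compound 2, whose number lies higher by a margin beyond the scatter.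

Compound 4, with the structure `CN(C)C(=O)CCNC(=O)c1cc(-c2ccc(F)cc2)no1`, has not yet been measured in this assay. It differs from compound 3 by a single change: hydrogen in place of methyl on a saturated chain carbon bound to a carbonyl carbon and a saturated chain carbon. Within the data shown here, no step between two measured compounds isolates this change, so its effect is unknown from the present set.

Since only compound 3 offers a starting point, its value 52% anchors the expectation, and the step is expected to be small and of uncertain direction, likely not beyond the scatter, as a number 4 percentage points lower from compound 3 to compound 4 (within the scatter). Compound 4 is therefore estimated to give 48% in this assay, within a range from 30% to 66%.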

Compound 4, percent of the compound remaining: 10%
Beside the measured number, compound 4's estimate is 38 percentage points above it, outside the stated range (below it).
By their numbers in this assay, from the lowest: compound 4; then compounds 1 and 3 (each within the scatter of the next); then compound 2.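

In this assay the set now holds its first step that isolates a single place, and that step is large: a number 42 percentage points lower from compound 3 to compound 4 (beyond the scatter). The earlier compounds shown here differ from one another in several places at once and could not show that this read-out is so sensitive to one methyl on a saturated chain carbon bound to a carbonyl carbon and a saturated chain carbon; here, the change from 1-(dimethylcarbamoyl)ethyl to (dimethylcarbamoyl)methyl is the only difference, and it costs far more than the usual scatter. Nothing in the data explains why this small change has so large an effect.

The compounds shown leave open whether an ethyl group, a second methyl, a cyclopropane ring or a fluorine on this same carbon would match compound 3, surpass it or fall short of it. They also leave open whether the methyl would count for as much if a carboxylic acid or an amine stood in place of the dimethylcarbamoyl group.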